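The source may hold more compounds than are shown below. What is called first, only, known or untested is meant among the compounds shown, and "the series" means these compounds.

Measured compounds in hand:
compound 1, `C/C(=C\c1cc(-c2cccnc2)co1)C(N)=O` — 13200 nM
compound 2, `C/C(=C\c1cc(-c2ccc(C#N)cc2)cs1)C(N)=O` — 240 nM

In a functional assay on MCF7 cells (Homo sapiens) for cytotoxicity, read by CCK-8 assay, with a stated time of 24 h (on this read-out lower numbers stand for stronger inhibition and higher numbers for weaker inhibition), compound 1 gives 13200 nM. In this assay compound 2 gives 240 nM. Going by the values given here, of the two numbers recorded, compound 2 holds the lower one, and its only neighbour, compound 1, sits far above it, a gap well beyond the usual scatter of this kind of measurement. The two compounds differ in more than one place, so their values alone show no single cause.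

Compound 3, `C/C(=C\c1cc(-c2ccc(C(F)(F)F)cc2)cs1)C(N)=O`, is the next compound to be measured. It differs from compound 2 in one place: trifluoromethyl in place of cyano on an aromatic carbon. Among the compounds with values here, no pair among the measured compounds shows a change of this kind, so there is no measured step to lean on. The change keeps the rest of the structure of compound 2 intact, and the expectation is a small step in this assay, at most a mild weakening and quite possibly none beyond the scatter. Compound 3 is therefore estimated at 350 nM, with a range from 100 nM to 1500 nM, which means an expected step of a 1.5-fold higher number from compound 2 to compound 3 (0.16 log units; within the scatter).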

Compound 3, half-maximal inhibitory concentration: 50000 nM
Compound 3: middle estimate off by 140-fold (2.15 log units), on the low side; the whole stated range lies below it.
By their numbers in this assay, from the lowest: compound 2; then compound 1; then compound 3.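

In this assay, putting trifluoromethyl in place of cyano on an aromatic carbon of the six-membered aromatic ring of carbon only, para to a large group, gives a 210-fold higher number from compound 2 to compound 3 (2.32 log units; beyond the scatter), a large step well beyond the scatter. This is the first change in a single place among these compounds, and it shows that the read-out at this position depends strongly on which group stands there: the rest of the structure of compound 2 is kept, so this one exchange accounts for the whole step. Nothing measured here gives a reason for the size of this step.

As far as these compounds go, a single pair cannot show whether the step reflects the departure of cyano, the arrival of trifluoromethyl, or both, so it remains open how a chlorine atom, a methoxy group or a carboxylic acid on the same carbon would compare with these two groups. From the compounds shown here alone, it also remains open whether the same exchange would give a step of similar size on the core of compound 1.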